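From a Ring Amine to a Propoxy Chain

The compounds below may be only part of what the source reports. "The series", "measured", "known", "first", "only" and "open" are said of these compounds alone.

Among the compounds with values here, compound 3 `CC(C(=O)NCc1ccc(C(F)(F)F)cc1N1CCC(C(F)(F)F)CC1)c1ccc(NS(C)(=O)=O)c(F)c1` gives 0.4 nM in an assay on CHO cells for antagonist activity at transient receptor potential cation channel subfamily V member 1 (Homo sapiens), read by FLIPR (a lower number here means a stronger inhibitor, a higher number a weaker inhibitor), the lowest of the three numbers measured so far. Compound 1 `CCCCN(C)c1cc(C(F)(F)F)ccc1CNC(=O)C(C)c1ccc(NS(C)(=O)=O)c(F)c1` gives 1.2 nM in this assay, and compound 2 `CC(C(=O)NCc1ccc(C(F)(F)F)cc1N1CCC(C)(C)CC1)c1ccc(NS(C)(=O)=O)c(F)c1` gives 1.3 nM. The step of a 3.0-fold lower number from compound 1 to compound 3 (0.48 log units; beyond the scatter) and the step of a 3.3-fold lower number from compound 2 to compound 3 (0.51 log units; beyond the scatter) are both modest and beyond the scatter, whereas the step of a 1.1-fold higher number from compound 1 to compound 2 (0.03 log units; within the scatter) lies within it.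

Compound 4 `CCCOc1cc(C(F)(F)F)ccc1CNC(=O)C(C)c1ccc(NS(C)(=O)=O)c(F)c1` has not yet been measured. It differs from compound 3 at one place: propoxy in place of 4-(trifluoromethyl)piperidin-1-yl on an aromatic carbon. Within the data shown here, no measured step covers propoxy at this carbon, so the expectation rests on the neighbouring changes. Those steps, a 3.0-fold lower number from compound 1 to compound 3 (0.48 log units; beyond the scatter) and a 3.3-fold lower number from compound 2 to compound 3 (0.51 log units; beyond the scatter), show that exchanging the group on this carbon has shifted the number by a modest amount, and they show that the open-chain amine of compound 1 and the ring of compound 2 gave numbers within the scatter of each other. On that basis compound 4 is expected to give a modestly higher number than compound 3. The expected step is a 5.0-fold higher number from compound 3 to compound 4 (0.70 log units; beyond the scatter). The estimate for compound 4 in this assay is 2 nM, with a range from 0.6 nM to 7 nM.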

Compound 4, inhibition constant: 2 nM
Compound 4: the middle estimate sits on the measured number at the digits printed; the range from low to high includes it.
By their numbers in this assay, from the lowest: compound 3; then compounds 1, 2 and 4 (each within the scatter of the next).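

Exchanging the 4-(trifluoromethyl)piperidin-1-yl group, with its 10 heavy atoms and its ring, for propoxy, with 4 heavy atoms and no ring, gives a 5.0-fold higher number from compound 3 to compound 4 (0.70 log units; beyond the scatter) in this assay. Against the two other groups at this aromatic carbon, the propoxy chain gives a 1.5-fold higher number from compound 2 to compound 4 (0.19 log units; within the scatter) and a 1.7-fold higher number from compound 1 to compound 4 (0.22 log units; within the scatter), both within the scatter, so neither a ring nor a nitrogen on this carbon is needed for a number of this size, and among the four compounds only compound 3 stands apart. No measurement given here bears on why this one group separates from the other three.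

The compounds shown leave open whether a trifluoromethyl group at the end of an open chain, as in a trifluoropropoxy group, would bring compound 4 level with compound 3, or whether that group counts only on the piperidine ring. They also leave open how an ethoxy group, a butoxy group or a morpholine ring would behave on this carbon.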